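Series notes: the step from compound 2 to compound 3

This account rests on a few compounds, and the source may have more. Where it says the series, first, only, none or still open, it means among the compounds named here.

Among the compounds with values here, compound 1 `CN(Cc1cc(C(F)(F)F)cc(C(F)(F)F)c1)C(=O)c1c(N2CCCC2)c2ccccc2n(C)c1=O` and compound 2 `CCOc1cc(CN(C)C(=O)c2c(OCCCC3CCN(C(=O)OC(C)(C)C)CC3)c3ccccc3n(C)c2=O)cc(OCC)c1` are the two measured members and share the core of compound 1. In an assay for inhibition of phosphatidylcholine:ceramide cholinephosphotransferase 2 (Mus musculus), read by mass spectrometry, with stated times of 60 min and 30 min (a higher number here means a weaker inhibitor, a lower number a stronger inhibitor), compound 1 gives 1100 nM, and compound 2 gives 51 nM. Compound 2 thus holds the lower of the two numbers, and its gap to compound 1 lies beyond the usual scatter. Compound 3 `COc1cc(CN(C)C(=O)c2c(OCCCC3CCN(C(=O)OC(C)(C)C)CC3)c3ccccc3n(C)c2=O)cc(OC)c1` is not yet measured and is built from compound 2 with one change: 3,5-dimethoxyphenyl in place of 3,5-diethoxyphenyl on a saturated chain carbon bound to an amide-type nitrogen. Within the data shown here, no measured pair differs in this way, so no step of this kind is available to fix the size of the effect. In this assay a small move toward a higher number, or none beyond the scatter, is expected: a 1.7-fold higher number from compound 2 to compound 3 (0.22 log units; within the scatter). Compound 3 is estimated at 85 nM, with a range from 30 nM to 250 nM.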

Compound 3, half-maximal inhibitory concentration in the phosphatidylcholine:ceramide cholinephosphotransferase 2 assay: 19 nM
For compound 3 the middle estimate is 4.5-fold (0.65 log units) above the measured one, and the stated range ends above it.
By their numbers in the phosphatidylcholine:ceramide cholinephosphotransferase 2 assay, from the lowest: compound 3; then compound 2; then compound 1.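

Replacing 3,5-diethoxyphenyl with 3,5-dimethoxyphenyl on a saturated chain carbon bound to an amide-type nitrogen gives, in the phosphatidylcholine:ceramide cholinephosphotransferase 2 assay, a 2.7-fold lower number from compound 2 to compound 3 (0.43 log units; beyond the scatter), so this position is sensitive to a change as small as this one. In a physicochemical assay for solubility, read by LC-MS, at pH 6.8 (on this read-out higher numbers stand for higher solubility and lower numbers for lower solubility), compound 2 gives < 0.08 ug/mL, which is a limit of the assay and not a number. In the physicochemical assay compound 3 gives 1.8 ug/mL, a measured number, so in this pair a lower number for inhibition and a measured reading come together.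

A single pair gives the direction of one step and no trend. As far as these compounds go, how the position responds to an unsubstituted phenyl, a 3,5-dipropoxyphenyl or a phenyl carrying an amine or a carboxylic acid remains open.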